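The source may report more compounds than this note shows. Statements on the series, on what has been measured and on what is new or still open speak of the compounds shown alone.

In a functional assay on EA.hy 926 cells (Homo sapiens) for cytotoxicity, read by MTT assay, with stated times of 24 h and 12 h, tested at 100 uM (on this read-out lower numbers stand for a weaker effect and higher numbers for a stronger effect at the one concentration tested), compound 2 `Cc1nc(C)c(C(=O)Oc2ccc(/C=C/C(=O)O)cc2O)nc1C` stands highest of the three numbers measured, giving 601%. Compound 1 `CCOC(=O)/C=C/c1cc(OC)ccc1OC(=O)c1nc(C)c(C)nc1C` gives 46.2% in this assay, and compound 3 `CCOC(=O)/C=C/c1ccccc1OC(=O)c1nc(C)c(C)nc1C` gives 40.9%. For the measured compounds named here, the one measured step, a number 5.3 percentage points lower from compound 1 to compound 3 (within the scatter), concerns a different site and does not bear on the change now considered. Compound 4 `CCOC(=O)/C=C/c1ccc(OC(=O)c2nc(C)c(C)nc2C)c(O)c1` differs from compound 2 by ethyl in place of hydrogen on an oxygen next to a carbonyl group, that is, carboxy becomes ethoxycarbonyl. Going by the values given here, no measured step covers this change; what is known is that compound 1 and compound 3, which both carry an ethoxycarbonyl group, sit far beneath compound 2. Compound 4 is therefore expected to fall toward their region, with a step of a number 541 percentage points lower from compound 2 to compound 4 (beyond the scatter) and an estimated value of 60%, ranging from 30% to 160%.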

Compound 4, a percentage reported as activity, at one concentration (the size of the read-out at that concentration, not a potency): 375%
Beside the measured number, compound 4's estimate is 315 percentage points below it; measured number outside the range, above it.
By their numbers in this assay, from the lowest: compounds 3 and 1 (each within the scatter of the next); then compound 4; then compound 2.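

In this assay, for the compounds shown here, the change from carboxy to ethoxycarbonyl gives a number 226 percentage points lower from compound 2 to compound 4 (beyond the scatter) and so shows for the first time that this site responds to what is placed on the oxygen. Even so, compound 4 keeps a high reading of 375% and the carboxy group is thus not needed for a number of this order. Nothing shown explains the size of this step. As far as these compounds go, whether a longer chain than ethyl on this oxygen would sit nearer compound 2 or compound 4 stays open. So does the effect of an amide in place of the ethoxycarbonyl group.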